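The compounds below may be only part of what the source reports. "The series", "measured", "known", "first", "only" and "open" are said of these compounds alone.

Measured in a functional assay on MCF7 cells (Homo sapiens) for inhibition, read by MTT assay, with a stated time of 48 h (on this read-out higher numbers stand for weaker inhibition and lower numbers for stronger inhibition), so far:
Compound 1 `Oc1cccc(C(c2c[nH]c3ccc(Br)cc23)c2c[nH]c3ccc(Br)cc23)c1` gives 2800 nM
Compound 2 `CN(C)c1ccc(C(c2c[nH]c3ccc(Br)cc23)c2c[nH]c3ccc(Br)cc23)cc1` gives 24900 nM
Compound 3 `Brc1ccc2[nH]cc(C(c3c[nH]c4ccc(Br)cc34)C3CCCCC3)c2c1` gives 4100 nM

Compound 3 stands close to one companion and well away from the other, with a 1.5-fold higher number from compound 1 to compound 3 (0.17 log units; within the scatter) against a 6.1-fold lower number from compound 2 to compound 3 (0.78 log units; beyond the scatter) on these numbers. Compound 4 `Brc1ccc2[nH]cc(C(c3ccc4ccccc4c3)c3c[nH]c4ccc(Br)cc34)c2c1` carries naphthalen-2-yl in place of cyclohexyl on a saturated chain carbon bound to two aromatic carbons, a change counted as naphthalen-2-yl in place of cyclohexyl on a saturated chain carbon bound to two aromatic carbons in full. Going by the values given here, the two steps above, together with an 8.9-fold higher number from compound 1 to compound 2 (0.95 log units; beyond the scatter) at that same carbon, are the only guides, and none involves naphthalen-2-yl. They show that an aromatic group there can match cyclohexyl or fall away modestly, so no step beyond the scatter is expected in this assay and no direction is favoured. The expected step is a 1.1-fold higher number from compound 3 to compound 4 (0.04 log units; within the scatter) as a rough guide. For compound 4 the estimated value is 4500 nM with an expected range from 1500 nM to 15000 nM overall.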

Compound 4, half-maximal inhibitory concentration: 7100 nM
For compound 4 the middle estimate is 1.6-fold (0.20 log units) below the measured one; the measured number falls inside the stated range.
By their numbers in this assay, from the lowest: compounds 1, 3 and 4 (each within the scatter of the next, the first and the last beyond it); then compound 2.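

In this assay, naphthalen-2-yl, with its 10 heavy atoms, stays within the scatter of cyclohexyl on the saturated chain carbon, with a 1.7-fold higher number from compound 3 to compound 4 (0.24 log units; within the scatter). Yet it stands apart from both substituted phenyl groups, in opposite directions, with a 3.5-fold lower number from compound 2 to compound 4 (0.54 log units; beyond the scatter) and a 2.5-fold higher number from compound 1 to compound 4 (0.40 log units; beyond the scatter), so an aromatic group at this carbon does not by itself fix the number. Nothing available here accounts for these steps. As far as these compounds go, how a plain phenyl, a methyl or a benzoic acid group would read at this carbon remains open.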